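Aryl swap at the hydrazone imine carbon

The source may report more compounds than this note shows. Statements on the series, on what has been measured and on what is new or still open speak of the compounds shown alone.

In a functional assay on MCF7 cells (Homo sapiens) for antiproliferative activity, read by MTT assay, with a stated time of 72 h (a higher number here means a weaker inhibitor, a lower number a stronger inhibitor), compound 1 `CCCSc1nc(N/N=C/c2c[nH]c3ccccc23)c2nnn(Cc3ccccc3)c2n1` gives 9010 nM. In this assay compound 2 `CCCSc1nc(N/N=C/c2ccc(N(C)C)cc2)c2nnn(Cc3ccccc3)c2n1` gives 12200 nM, the higher of the two numbers shown, though its gap to compound 1 lies within the scatter. The step of a 1.4-fold higher number from compound 1 to compound 2 (0.13 log units; within the scatter) shows no change beyond the scatter. Compound 3 `CCCSc1nc(N/N=C/c2ccc3ccccc3c2)c2nnn(Cc3ccccc3)c2n1` carries naphthalen-2-yl in place of 4-(dimethylamino)phenyl on a carbon with a double bond to nitrogen. Among the compounds with values here, that aryl swap on the imine carbon is the one measured step that bears here, and it stayed within the scatter. Compound 3 is therefore expected to move by a 1.2-fold lower number from compound 2 to compound 3 (0.09 log units; within the scatter), no real shift. The estimate for compound 3 in this assay is 10000 nM, between 3500 nM and 28000 nM.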

Compound 3, half-maximal inhibitory concentration: > 64000 nM
Compound 3 was reported as a limit; the forecaster's own chance of this, stated with the estimate: 5%; middle value at least 6.4-fold (0.80 log units) away from the limit.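

The hydrazone imine carbon is not indifferent to the aryl group: in this assay, naphthalen-2-yl in place of 4-(dimethylamino)phenyl gives an at least 5.2-fold higher number from compound 2 to compound 3 (0.71 log units; beyond the scatter), and naphthalen-2-yl in place of 1H-indol-3-yl gives an at least 7.1-fold higher number from compound 1 to compound 3 (0.85 log units; beyond the scatter). The earlier swap, between the two nitrogen-bearing groups, showed no change beyond the scatter. Compound 3 is reported only as a limit: the limit of > 64000 nM in this assay, at which 1 of the 3 values shown sits.

Going by these compounds, the true size of both steps stays open past that limit. Also open, on these data alone, is whether a plain phenyl or a pyridinyl group on this carbon behaves like the groups of compound 1 and compound 2 or like naphthalen-2-yl.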